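One Methyl, Two Placements, Same Core

The source may hold more compounds than are shown below. What is called first, only, known or untested is meant among the compounds shown, and "the series" means these compounds.

Compound 2 `Cc1cccc(NC(=O)c2cc3ccccc3oc2=O)c1` carries a methyl on the ring attached to the amide nitrogen, while compound 1 `O=C(Nc1ccccc1)c1cc2ccccc2oc1=O` has hydrogen there. In an in vitro assay on BTI-TN-5B1-4 cells for inhibition of Amine oxidase [flavin-containing] A (Homo sapiens), read by fluorescence (a higher number here means a weaker inhibitor, a lower number a stronger inhibitor), compound 2 gives 14500 nM, and compound 1 gives 13100 nM; the two sit within the scatter of each other, the step of a 1.1-fold higher number from compound 1 to compound 2 (0.04 log units; within the scatter) being small. Compound 3 `Cc1ccc(NC(=O)c2cc3ccccc3oc2=O)cc1` differs from compound 2 by 4-methylphenyl in place of 3-methylphenyl on an amide-type nitrogen. Among the measured compounds shown here, no measured step moves a methyl in this way, and adding it hardly mattered in a 1.1-fold higher number from compound 1 to compound 2 (0.04 log units; within the scatter), so for compound 3 the estimated step is a 1.0-fold lower number from compound 2 to compound 3 (0.02 log units; within the scatter). Compound 3 is expected to give about 14000 nM in this assay, likely between 7000 nM and 28000 nM.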

Compound 3, half-maximal inhibitory concentration: 19500 nM
Compound 3: the middle estimate sits 1.4-fold (0.14 log units) below what was measured; the measured number falls inside the stated range.
By their numbers in this assay, from the lowest: compounds 1, 2 and 3 (each within the scatter of the next).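

Shifting the methyl from 3-methylphenyl to 4-methylphenyl gives a 1.3-fold higher number from compound 2 to compound 3 (0.13 log units; within the scatter) in this assay, and setting that 4-methylphenyl against the unsubstituted ring gives a 1.5-fold higher number from compound 1 to compound 3 (0.17 log units; within the scatter). Both steps lie within the scatter, so neither methyl placement shown separates from hydrogen or from the other placement. Nothing shown here offers an explanation for these numbers.

Going by these compounds, whether a methoxy group, a chlorine or a carboxylic acid on this ring would move the number beyond the scatter stays open. So does what a change on the shared core would do.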